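This account rests on a few compounds, and the source may have more. Where it says the series, first, only, none or still open, it means among the compounds named here.

Measured compounds in a functional assay on M21 cells (Homo sapiens) for inhibition, read by sulforhodamine B assay, with a stated time of 48 h; a lower number here means a stronger inhibitor, a higher number a weaker inhibitor:

Compound 1 `CCNC(=O)Nc1ccc(/C=C\c2cccc(Cl)c2)cc1` gives 35000 nM.
Compound 2 `CCNC(=O)Nc1ccc(/C=C\c2cc(OC)c(OC)c(OC)c2)cc1` gives 21000 nM.
Compound 3 `COc1cc(/C=C\c2ccc(N3CCNC3=O)cc2)cc(OC)c1OC` gives 2.4 nM.

Compound 1 and compound 2 lie within the scatter of each other, so no order is drawn between them; the difference between their two cores is not broken down here. For the measured compounds named here, the one structural change that is documented, (2-oxoimidazolidin-1-yl in place of (ethylcarbamoyl)amino on an aromatic carbon), brings the step of an 8800-fold lower number from compound 2 to compound 3 (3.94 log units; beyond the scatter).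

Compound 4 `O=C1NCCN1c1ccc(/C=C\c2cccc(Cl)c2)cc1` applies the same kind of change to the core of compound 1: 2-oxoimidazolidin-1-yl in place of (ethylcarbamoyl)amino on an aromatic carbon. The surroundings of the place are not identical in wording, para to a group of 9 heavy atoms here against para to a large group in the earlier pair, so the two changes are of the same kind rather than the same.

For compound 4 a step of a 2900-fold lower number from compound 1 to compound 4 (3.46 log units; beyond the scatter) in this assay is expected, because an 8800-fold lower number from compound 2 to compound 3 (3.94 log units; beyond the scatter) was the effect of this change on the other core, while compound 1 and compound 2 start from values within the scatter of each other. The estimate for compound 4 is therefore 12 nM, with a range from 2 nM to 120 nM.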

Compound 4, half-maximal inhibitory concentration: 27 nM
Compound 4: the middle estimate sits 2.3-fold (0.35 log units) below what was measured, within the range that was stated.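

Carried to the core of compound 1, the change gives a 1300-fold lower number from compound 1 to compound 4 (3.11 log units; beyond the scatter) in this assay and so lowers the number strongly on both cores shown. The direction of the step holds, but its size does not carry over unchanged: the same change on two cores in this assay, an 8800-fold lower number (3.94 log units; beyond the scatter) from compound 2 to compound 3 and a 1300-fold lower number (3.11 log units; beyond the scatter) from compound 1 to compound 4, 6.8-fold (0.83 log units) apart, beyond the scatter of two such steps.

For the compounds shown here, with only two cores, the series gives no rule for the size of the step on a further core, and these data do not tell what in the cores sets the gap between the two steps.

The compounds shown leave open whether the lower numbers go with the closed five-membered ring itself or with the loss of a hydrogen-bond donor, a question that a methyl group on the ring nitrogen of 2-oxoimidazolidin-1-yl would bear on. Also open, from the compounds shown here alone, is how the step would run on a core carrying an amine or a carboxylic acid in place of the chloro group of compound 4.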